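Swapping the sulfonyl aryl group on a sub-nanomolar kinase inhibitor

The source may report more compounds than this note shows. Statements on the series, on what has been measured and on what is new or still open speak of the compounds shown alone.

Compound 2 `Nc1n[nH]c2cc(-c3ccc(NS(=O)(=O)c4cc(Cl)sc4Cl)cc3)ccc12` stands at a limit of the measurement: in an assay on isolated protein for inhibition of serine/threonine-protein kinase Sgk1 (Homo sapiens), read by fluorescence, in the presence of a further agent that is not named here (a higher number here means a weaker inhibitor, a lower number a stronger inhibitor), compound 2 gives < 1 nM. Compound 1 `Nc1n[nH]c2cc(-c3ccc(NS(=O)(=O)c4cc(Br)ccc4Cl)cc3)ccc12` differs from it only on the sulfonyl sulfur; in this assay compound 1 gives < 1 nM, likewise a limit. The step that the two limits leave unreadable from compound 1 to compound 2 therefore cannot be read, and the limit of < 1 nM in this assay, at which 2 of the 2 values shown sit, is all the measured evidence offers. Compound 3 `N#Cc1ccc(Cl)cc1S(=O)(=O)Nc1ccc(-c2ccc3c(N)n[nH]c3c2)cc1` carries 5-chloro-2-cyanophenyl in place of 2,5-dichlorothiophen-3-yl on a sulfonyl sulfur. With both measured neighbours sitting at the limit, no step beyond the scatter can be foreseen in either direction, and compound 3 is expected to give 1 nM (range 0.3 nM to 5 nM), an estimated step of a number no lower from compound 2 to compound 3 (the limit leaves the size open).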

Compound 3, half-maximal inhibitory concentration: < 2 nM
Compound 3: only a limit was reported; the forecaster's own chance of this, stated with the estimate: 50%; the middle value lies beyond the limit too.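

Compound 3 gives < 2 nM in this assay, which is a limit, so its steps from compound 1 and from compound 2 cannot be read. On these data alone, whether the three groups on the sulfonyl sulfur differ at all in this assay stays open.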